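The source may report more compounds than this note shows. Statements on the series, on what has been measured and on what is new or still open speak of the compounds shown alone.

Measured so far:
Compound 1 `CCNC(=O)[C@H]1O[C@@H](n2cnc3c(NNC(=O)c4ccc(Br)o4)ncnc32)[C@H](O)[C@@H]1O` — in a functional assay on CHO cells for activation of adenosine receptor A2b (Homo sapiens), read by cAMP accumulation (on this read-out higher numbers stand for an effect only at larger amounts of compound and lower numbers for an effect already at smaller amounts), compound 1 gives 369 nM.
Compound 2 `CCNC(=O)[C@H]1O[C@@H](n2cnc3c(NNC(=O)c4ccco4)nc(Cl)nc32)[C@H](O)[C@@H]1O` — in this assay compound 2 gives 210 nM.

Compound 2 holds the lower of the two numbers, yet its value and that of compound 1 lie within the usual scatter of each other, so the two cannot really be told apart on this read-out. Compound 3 `CCNC(=O)[C@H]1O[C@@H](n2cnc3c(NNC(=O)c4cc(-c5ccccc5)on4)nc(Cl)nc32)[C@H](O)[C@@H]1O` has not been measured; it keeps the core of compound 2 and differs from it in a single place: 5-phenyl-1,2-oxazol-3-yl in place of furan-2-yl on a carbonyl carbon. Among the measured compounds shown here, no measured pair of compounds shows what such a swap does on this read-out, so there is nothing to anchor the direction. With no guide beyond the two values shown, the expected step from compound 2 to compound 3, a 1.7-fold higher number from compound 2 to compound 3 (0.22 log units; within the scatter), is a modest loss that may well stay inside the scatter. Compound 3 is therefore estimated at 350 nM, with a range from 100 nM to 1500 nM.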

Compound 3, half-maximal effective concentration: > 5000 nM
Compound 3: no number, only a limit; the forecaster's own chance of this, stated with the estimate: 10%; middle value at least 14-fold (1.15 log units) from the limit.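

Setting 5-phenyl-1,2-oxazol-3-yl in place of furan-2-yl on a carbonyl carbon gives an at least 23-fold higher number from compound 2 to compound 3 (1.37 log units; beyond the scatter) in this assay, so this position does not accept every aromatic group equally. Compounds 1 and 2 differ in more than one place, so they could not show this; here, a change at this position alone can be read. Compound 3 has a limit of the assay and not a number: the limit of > 5000 nM in this assay, at which 1 of the 3 values shown sits.

The change swaps one five-membered ring for another and adds a phenyl ring in the same step, so the compounds shown do not tell which of the two goes with the loss. A plain 1,2-oxazol-3-yl group, or a furan-2-yl group carrying a phenyl ring, would separate the two.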